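A few compounds are considered here, and "the series" means these few. Any claim that something is new, unique, unknown or untested is made for them only; others in the source may bear on it.

Measured so far:
Compound 1 `Cn1cnc(S(=O)(=O)N(Cc2ccc(S(C)(=O)=O)cc2)C2Cc3cc(C#N)ccc3N(Cc3cncn3C)C2)c1`: 16 h
Compound 2 `Cn1cncc1CN1C(=O)C(N(CC(=O)NC(C)(C)C)S(=O)(=O)c2cccc(F)c2)Cc2cc(C#N)ccc21`: 31 h
Compound 3 `Cn1cnc(S(=O)(=O)N(Cc2ccc(-n3cccn3)cc2)C2Cc3cc(C#N)ccc3N(Cc3cncn3C)C2=O)c1`: 9 h

In an in vitro ADME assay on microsomes from liver (Mus musculus) for metabolic stability (on this read-out higher numbers stand for a longer-lived compound and lower numbers for a shorter-lived compound), compound 3 gives the smallest of the three numbers; against compound 1 the gap is within the scatter, while against compound 2 it lies beyond it. No pair of these compounds differs in one place only, so no single step is set by the measured values.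

Compound 4 `Cn1cnc(S(=O)(=O)N(Cc2ccc(S(C)(=O)=O)cc2)C2Cc3cc(C#N)ccc3N(Cc3cncn3C)C2=O)c1` differs from compound 3 in one place: methylsulfonyl in place of 1H-pyrazol-1-yl on an aromatic carbon. Compound 1 carries the same methylsulfonyl group and gives 16 h in this assay. Among the compounds with values here, no measured step isolates this exchange. The step from compound 3 to compound 4 is expected to be a 1.3-fold higher number from compound 3 to compound 4 (0.12 log units; within the scatter), a small rise that stays within the scatter. Compound 4 is therefore estimated at 12 h, with a range from 6 h to 24 h.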

Compound 4, half-life: 133 h
For compound 4 the middle estimate is 11-fold (1.04 log units) below the measured one; the measured number lies above the stated range.
By their numbers in this assay, from the lowest: compounds 3, 1 and 2 (each within the scatter of the next, the first and the last beyond it); then compound 4.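

On this aromatic carbon, para to a large group, methylsulfonyl in place of 1H-pyrazol-1-yl gives a 15-fold higher number from compound 3 to compound 4 (1.17 log units; beyond the scatter) in this assay, although the counts of hydrogen-bond donors and acceptors stay the same. Methylsulfonyl alone does not set the number: compound 1, which carries it without the carbonyl of the core, gives 16 h, against 133 h for compound 4. Nothing measured here bears on the reason for this step.

Open, as far as these compounds go, is whether an amine or a carboxylic acid on this carbon would keep the half-life of compound 4. Also open, from the compounds shown here alone, is whether the same exchange gives a step of this size on the core of compound 1.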